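Swapping thiophen-2-yl for 4-methylbenzyl on the shared core

This account rests on a few compounds, and the source may have more. Where it says the series, first, only, none or still open, it means among the compounds named here.

Of the compounds shown here, two have been measured so far. In a functional assay on HL-60 cells (Homo sapiens) for inhibition, read by CCK-8 assay, with a stated time of 48 h (on this read-out lower numbers stand for stronger inhibition and higher numbers for weaker inhibition), compound 1 (`COc1ccc(S(=O)(=O)Oc2ccccc2/C=C(\C#N)C(=O)Nc2nnc(-c3cccs3)s2)cc1`) gives 5230 nM as its half-maximal inhibitory concentration, and compound 2 (`CC(=O)Nc1ccc(S(=O)(=O)Oc2cccc(/C=C(\C#N)C(=O)Nc3nnc(-c4cccs4)s3)c2)cc1`) gives 7940 nM on the same read-out. These two values lie within the usual scatter of each other, so compound 1 stands level with compound 2 on the numbers available.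

Compound 3 (`COc1ccc(S(=O)(=O)Oc2ccccc2/C=C(\C#N)C(=O)Nc2nnc(Cc3ccc(C)cc3)s2)cc1`) keeps the core of compound 1 but carries 4-methylbenzyl in place of thiophen-2-yl on an aromatic carbon. Going by the values given here, no measured pair shows what a change at this place does, and compound 2 differs from compound 1 elsewhere in the structure. The expectation therefore starts from compound 1 at 5230 nM and assumes no clear movement in this assay in either direction. The estimated change is small (a 1.1-fold higher number from compound 1 to compound 3 (0.06 log units; within the scatter)) and is expected to stay within the scatter. In this assay the estimate for compound 3 is 6000 nM with an expected range from 2000 nM to 18000 nM for this compound.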

Compound 3, half-maximal inhibitory concentration: 4080 nM
For compound 3 the middle estimate is 1.5-fold (0.17 log units) above the measured one, within the range that was stated.
By their numbers in this assay, from the lowest: compounds 3, 1 and 2 (each within the scatter of the next).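

In this assay, going by these compounds alone, the step from thiophen-2-yl to 4-methylbenzyl gives the first reading at this position on the five-membered aromatic ring with 2 nitrogen and 1 sulfur: a 1.3-fold lower number from compound 1 to compound 3 (0.11 log units; within the scatter). The two groups differ in ring size, in the sulfur of the leaving ring, in the hydrogen-bond acceptor counted for it, and in the methyl-bearing benzyl of the group that enters, yet compound 1 and compound 3 stand level on this read-out, so this single pair shows no sign that the exchange matters here. Nothing measured alongside these numbers offers an explanation for the two groups standing level.

The compounds shown leave open whether this position would stay as indifferent with a group of another kind, such as an amine, a carboxylic acid or a longer alkyl chain, since both groups compared here carry an aromatic ring. They also leave open whether 4-methylbenzyl would read the same on the structure of compound 2, which differs from compound 1 elsewhere and has no partner carrying this group.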